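Compound 3 to compound 4: methyl to ethyl

This account rests on a few compounds, and the source may have more. Where it says the series, first, only, none or still open, it means among the compounds named here.

In a functional assay on K562 cells (Homo sapiens) for inhibition, read by CCK-8 assay, with a stated time of 72 h (a lower number here means a stronger inhibitor, a higher number a weaker inhibitor), compound 1 `O=C(/C=C/c1cccnc1)NCCCCCc1ccc(S(=O)(=O)Nc2ccccc2)cc1` gives 146 nM and compound 2 `O=C(/C=C/c1cccnc1)NCCCCCc1cccc(S(=O)(=O)Nc2ccccc2)c1` gives 16.3 nM. Compound 3 `Cc1ccc(NS(=O)(=O)c2cccc(CCCCCCNC(=O)/C=C/c3cccnc3)c2)cc1` gives 2.98 nM, the lowest of the three numbers and beyond the scatter of both others.

Compound 4 `CCc1ccc(NS(=O)(=O)c2cccc(CCCCCCNC(=O)/C=C/c3cccnc3)c2)cc1` takes compound 3 from 4-methylphenyl to 4-ethylphenyl: methyl in place of hydrogen on a saturated chain carbon bound to an aromatic carbon.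

Among the measured compounds shown here, no pair of measured compounds differs in one place only, so the series gives no direct measure of a change of this kind. With so little to go on, the expectation in this assay is a small step that stays within the scatter, with a slight lean towards a higher number. The expected change is a 1.3-fold higher number from compound 3 to compound 4 (0.13 log units; within the scatter). For compound 4 the estimated value is 4 nM, with an expected range of 1.5 nM to 11 nM.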

Compound 4, half-maximal inhibitory concentration: 3.89 nM
Beside the measured number, compound 4's estimate is 1.0-fold (0.01 log units) above it; measured number inside the range.
By their numbers in this assay, from the lowest: compounds 3 and 4 (each within the scatter of the next); then compound 2; then compound 1.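

In this assay, among the compounds shown here, the move from 4-methylphenyl to 4-ethylphenyl gives a 1.3-fold higher number from compound 3 to compound 4 (0.12 log units; within the scatter), the first step that isolates a single place. For the compounds shown here, at this position, methyl in place of hydrogen on a saturated chain carbon bound to an aromatic carbon leaves compound 3 and compound 4 within the scatter of each other, a reading that the earlier compounds could not give. No supporting measurement bears on this result.

From the compounds shown here alone, it remains open whether the same holds for a propyl or tert-butyl group, or for an amine or a carboxylic acid, in place of the ethyl. Going by these compounds, compound 2 and compound 3 differ in more than one place, so what the 4-methylphenyl group contributes on its own also stays open.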